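A few compounds are considered here, and "the series" means these few. Any claim that something is new, unique, unknown or untested is made for them only; others in the source may bear on it.

In a functional assay on HeLa cells (Homo sapiens) for antiproliferative activity, read by cell counting, with a stated time of 72 h (a higher number here means a weaker inhibitor, a lower number a stronger inhibitor), compound 1 `C#C[C@@]1(O)[C@@H](CO)O[C@@H](n2cc(I)c3c(Cl)ccnc32)[C@@H]1O` gives 1100 nM and compound 2 `C#C[C@@]1(O)[C@@H](CO)O[C@@H](n2cc(Cl)c3c(N)ccnc32)[C@@H]1O` gives 1700 nM within the scatter of each other. Compound 3 `C#C[C@@]1(O)[C@@H](CO)O[C@@H](n2cc(I)c3c(N)ccnc32)[C@@H]1O` arises from compound 2 through iodo in place of chloro on an aromatic carbon as iodo in place of chloro on an aromatic carbon. Among the measured compounds shown here, no measured pair isolates this change. Compound 1 also bears iodo and gives 1100 nM with a different group elsewhere on the shared core, which is thin support. The expected change, estimated as a 2.1-fold lower number from compound 2 to compound 3 (0.33 log units; beyond the scatter) in this assay is a small move toward a lower number, near the edge of the scatter. Compound 3 is expected at 800 nM with an estimated range of 150 nM to 3000 nM for this measurement.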

Compound 3, half-maximal inhibitory concentration: 180 nM
For compound 3 the middle estimate is 4.4-fold (0.65 log units) above the measured one; low and high end bracket the measured number.
By their numbers in this assay, from the lowest: compound 3; then compounds 1 and 2 (each within the scatter of the next).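

In this assay, iodo in place of chloro on the aromatic carbon of the five-membered ring gives a 9.4-fold lower number from compound 2 to compound 3 (0.98 log units; beyond the scatter) with the amino group held constant, so this position distinguishes between the two halogens. With iodo held constant, exchanging the remaining chloro for amino gives a 6.1-fold lower number from compound 1 to compound 3 (0.79 log units; beyond the scatter) as a second, separate step on the shared core. Nothing available accounts for either step.

From the compounds shown here alone, only chloro and iodo appear at the five-membered ring position, so a bromo or methyl group there remains untested. Going by these compounds, whether a methylamino group could replace amino also remains open.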